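Swapping the aryl sulfide for a dimethylamino group

This account rests on a few compounds, and the source may have more. Where it says the series, first, only, none or still open, it means among the compounds named here.

Within the data shown here, compound 2 `Cc1nn(C)c(Sc2ccccc2)c1/C=N/OCc1ccc(C(=O)OC(C)(C)C)cc1` stands at the higher of the two numbers known so far: in a functional assay on HCT-15 cells (Homo sapiens) for cytotoxicity (on this read-out lower numbers stand for stronger inhibition and higher numbers for weaker inhibition), compound 2 gives 0.26 ug/mL, whereas compound 1 `Cc1nn(C)c(Oc2ccc(Cl)cc2)c1/C=N/OCc1ccc(C(=O)OC(C)(C)C)cc1` gives 0.01 ug/mL. The step of a 26-fold higher number from compound 1 to compound 2 (1.41 log units; beyond the scatter) shows that this position responds strongly to change. Compound 3 `Cc1nn(C)c(N(C)C)c1/C=N/OCc1ccc(C(=O)OC(C)(C)C)cc1` carries the next alteration: dimethylamino in place of phenylsulfanyl on an aromatic carbon. Among the measured compounds shown here, no measured step covers this exchange, so the expectation rests on the large shift already seen at the same position. Compound 3 is therefore expected to land near 1 ug/mL, within 0.15 ug/mL to 8 ug/mL, a step of a 3.8-fold higher number from compound 2 to compound 3 (0.59 log units; beyond the scatter) toward a weaker read-out.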

Compound 3, half-maximal inhibitory concentration: 6.22 ug/mL
Compound 3: middle estimate off by 6.2-fold (0.79 log units), on the low side, within the range that was stated.
By their numbers in this assay, from the lowest: compound 1; then compound 2; then compound 3.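

In this assay the exchange gives a 24-fold higher number from compound 2 to compound 3 (1.38 log units; beyond the scatter) and so shows that a group with no ring at this position sits far from both aryl-bearing groups. The span across this one position, a 620-fold higher number from compound 1 to compound 3 (2.79 log units; beyond the scatter) at its widest, places the two groups carrying a six-membered aromatic ring at the lower numbers, and none of these compounds goes against that. Nothing available explains the loss. The compounds shown leave open whether a saturated ring such as piperidine would behave like dimethylamino, and whether an unsubstituted phenoxy group would stay near compound 1 or compound 2.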